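The source may hold more compounds than are shown below. What is called first, only, known or untested is meant among the compounds shown, and "the series" means these compounds.

Measured so far in an assay on cells (Endothelial cell) for binding affinity to Endothelin-1 receptor (Sus scrofa) (on this read-out higher numbers stand for weaker inhibition and lower numbers for stronger inhibition), are compound 1 `COc1cccc(Oc2c(NS(=O)(=O)c3ccc(C(C)(C)C)cc3)ncnc2OCCOc2ccccc2)c1` with 65 nM, compound 2 `COCCOc1ncnc(NS(=O)(=O)c2ccc(C(C)(C)C)cc2)c1Oc1cccc(OC)c1` with 92 nM, and compound 3 `COc1cccc(Oc2c(NS(=O)(=O)c3ccc(C(C)(C)C)cc3)ncnc2OCCOc2ccncn2)c1` with 1.2 nM.

Compound 3 stands lowest of the three numbers: a 54-fold lower number from compound 1 to compound 3 (1.73 log units; beyond the scatter) and a 77-fold lower number from compound 2 to compound 3 (1.88 log units; beyond the scatter), both beyond the scatter, whereas a 1.4-fold higher number from compound 1 to compound 2 (0.15 log units; within the scatter). Compound 4 `COc1cccc(Oc2c(NS(=O)(=O)c3ccc(C(C)(C)C)cc3)ncnc2OCCOc2ncc(Br)cn2)c1` differs from compound 3 by 5-bromopyrimidin-2-yl in place of pyrimidin-4-yl on an oxygen on a saturated carbon. Within the data shown here, the two large steps into compound 3 show that the pyrimidin-4-yl on that oxygen carries most of the gain; no measured step exchanges one pyrimidinyl for another, so the size of this step is uncertain. Compound 4 is expected to keep much of that gain, with a 4.2-fold higher number from compound 3 to compound 4 (0.62 log units; beyond the scatter) estimated as a modest loss, giving about 5 nM in this assay, within 1 nM to 30 nM.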

Compound 4, half-maximal inhibitory concentration: 0.051 nM
Compound 4: the middle estimate sits 98-fold (1.99 log units) above what was measured; the measured number lies below the stated range.
By their numbers in this assay, from the lowest: compound 4; then compound 3; then compounds 1 and 2 (each within the scatter of the next).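

The gain on this oxygen does not end with the pyrimidin-4-yl: in this assay there is a 24-fold lower number from compound 3 to compound 4 (1.37 log units; beyond the scatter), although both groups hold one six-membered aromatic ring with 2 hetero atoms and 2 hydrogen-bond acceptors. The position therefore separates two closely related rings, and its full range now spans a 1800-fold lower number from compound 2 to compound 4 (3.26 log units; beyond the scatter) and a 1300-fold lower number from compound 1 to compound 4 (3.11 log units; beyond the scatter). Nothing at hand explains why the 5-bromopyrimidin-2-yl gives the lowest number.

Going by these compounds, the bromine and the change of ring attachment arrive together, so their separate shares remain unknown. An unsubstituted pyrimidin-2-yl or a 5-chloropyrimidin-2-yl on this oxygen would be needed to separate them.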